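This account rests on a few compounds, and the source may have more. Where it says the series, first, only, none or still open, it means among the compounds named here.

Working notes on the series. Going by the values given here, in a functional assay on A549 cells (Homo sapiens) for cytotoxicity, read by MTT assay, with a stated time of 72 h (on this read-out lower numbers stand for stronger inhibition and higher numbers for weaker inhibition), compound 1 `CN(C)Cc1ccc2nc(NC(=O)N/N=C/c3c[nH]c4ccccc34)sc2c1` gives 3300 nM, and compound 2 `Cc1ccc(Cn2cc(/C=N/NC(=O)Nc3nc4ccc(CN(C)C)cc4s3)c3ccccc32)cc1` gives 1600 nM, the lower of the two numbers so far. Among the compounds with values here, the only measured step, a 2.1-fold lower number from compound 1 to compound 2 (0.31 log units; beyond the scatter), puts 4-methylbenzyl in place of hydrogen on an aromatic nitrogen. It is modest and lies just beyond the scatter.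

Compound 3 `CN(C)Cc1ccc2nc(NC(=O)N/N=C/c3cn(Cc4cccc(Cl)c4)c4ccccc34)sc2c1` differs from compound 2 in one place: 3-chlorophenyl in place of 4-methylphenyl on a saturated chain carbon bound to an aromatic nitrogen. This is 3-chlorophenyl in place of 4-methylphenyl on a saturated chain carbon bound to an aromatic nitrogen. Within the data shown here, no measured pair compares two substituted benzyl groups, so the single modest step is the only guide to size, and no shift beyond the scatter is expected in this assay. The expected result is a 1.1-fold lower number from compound 2 to compound 3 (0.03 log units; within the scatter). Compound 3 is estimated at 1500 nM, with an expected range of 600 nM to 3800 nM.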

Compound 3, half-maximal inhibitory concentration: 1240 nM
Estimate against measurement, compound 3: 1.2-fold (0.08 log units) above, within the range that was stated.
By their numbers in this assay, from the lowest: compounds 3 and 2 (each within the scatter of the next); then compound 1.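

In this assay the change from 4-methylbenzyl to 3-chlorobenzyl gives a 1.3-fold lower number from compound 2 to compound 3 (0.11 log units; within the scatter) and so does not separate these two substituted benzyl groups. Substitution on the aromatic nitrogen now has a second example, with 3-chlorobenzyl in place of hydrogen giving a 2.7-fold lower number from compound 1 to compound 3 (0.43 log units; beyond the scatter) in the same direction as the 4-methylbenzyl step, so both substituted compounds lie beyond the scatter of compound 1 by modest margins. No supporting information bears on the origin of these numbers.

Compounds 2 and 3 differ in both the substituent and its ring position, so a 4-chlorobenzyl or 3-methylbenzyl group would be needed to read either change alone. Whether the aromatic ring of the benzyl group is needed also remains open, as a plain methyl group or a longer alkyl chain on that nitrogen is not among the compounds shown.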